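This account rests on a few compounds, and the source may have more. Where it says the series, first, only, none or still open, it means among the compounds named here.

Working notes on the series, covering the step from compound 1 to compound 3.

Among the compounds with values here, compound 1 `CN(c1ccccc1)S(=O)(=O)c1ccc(NC(=O)c2ccc(Cl)cc2Cl)cc1` is the lower of the two measured members. In a functional assay on HEK293 cells for agonist activity at probable G-protein coupled receptor 27 (Homo sapiens), read by a luciferase reporter and beta-arrestin recruitment, with a stated time of 10 min (a lower number here means a smaller maximal response, a higher number a larger maximal response), compound 1 gives 50%. Compound 2 `O=C(Nc1ccc(S(=O)(=O)Nc2ccccc2)cc1)c1ccc(Br)cc1F` is the nearer and only comparison; in this assay compound 2 gives 67%, a gap beyond the usual scatter, so compound 1 stands lowest of the two numbers available.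

Compound 3 `O=C(Nc1ccc(S(=O)(=O)Nc2cccc(Cl)c2)cc1)c1ccc(Cl)cc1Cl` has not yet been measured in this assay. Against compound 1 it differs in one place: (3-chlorophenyl)amino in place of methyl(phenyl)amino on a sulfonyl sulfur.

Within the data shown here, no measured pair isolates this change, so the direction rests on compound 2 alone. The step from compound 1 to compound 3 in this assay is expected to be upward, a number 14 percentage points higher from compound 1 to compound 3 (beyond the scatter), an expectation held with little confidence because compound 2 reaches 67%. For compound 3 the estimated maximal response in this assay is 64%, within a range from 44% to 84%.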

Compound 3, largest response reached (Emax), in percent of the reference or control that the assay uses: 40%
For compound 3 the middle estimate is 24 percentage points above the measured one; measured number below the stated range.
By their numbers in this assay, from the lowest: compounds 3 and 1 (each within the scatter of the next); then compound 2.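

In this assay, within the data shown here, the exchange of methyl(phenyl)amino for (3-chlorophenyl)amino on a sulfonyl sulfur gives a number 10 percentage points lower from compound 1 to compound 3 (within the scatter) and so provides the first one-place comparison at this position, with no separable shift in maximal response. The step brings in a chlorine and the hydrogen-bond donor counted for the entering group together, so compound 1 and compound 3 cannot show what either part contributes alone. No measured property bears on this result.

Still open, as far as these compounds go, is whether methyl(3-chlorophenyl)amino on the sulfonyl sulfur would separate the chlorine from the loss of the methyl. Also open, from the compounds shown here alone, is how a group without an aromatic ring, such as morpholine, would read at this position.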